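The source may hold more compounds than are shown below. What is called first, only, known or untested is meant among the compounds shown, and "the series" means these compounds.

Series notes. Compound 1 `O=C(NCc1ccc(S(=O)(=O)c2ccccc2)cc1)c1cc2cnccc2[nH]1` in a functional assay on A2780 cells (Homo sapiens) for cytotoxicity, read by sulforhodamine B assay, with a stated time of 72 h (on this read-out lower numbers stand for stronger inhibition and higher numbers for weaker inhibition), gives 18 nM. Compound 2 `O=C(NCc1ccc(S(=O)(=O)c2ccccc2)cc1)N1CCc2ccncc2C1` in this assay returns only a limit of the assay, > 2000 nM, not a number (the limit of > 2000 nM in this assay, at which 1 of the 3 values shown sits). Compound 3 `O=C(NCc1ccc(S(=O)(=O)C2CCOCC2)cc1)N1Cc2ccncc2C1` in this assay gives 35 nM; of the two numbers shown, compound 3 and compound 1 sit within the usual scatter of each other, so neither is placed ahead of the other. Compound 4 `O=C(NCc1ccc(S(=O)(=O)N2CCC[C@H](O)C2)cc1)N1Cc2ccncc2C1` has not been measured in this assay. It differs from compound 3 in one place: 3-hydroxypiperidin-1-yl in place of oxan-4-yl on a sulfonyl sulfur. For the measured compounds named here, no measured pair carries this change, so its size is open; a step beyond the scatter is not expected in either direction, with a small loss allowed for. The expected step is a 1.7-fold higher number from compound 3 to compound 4 (0.23 log units; within the scatter). The estimate for compound 4 in this assay is 60 nM, within 15 nM to 250 nM.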

Compound 4, half-maximal inhibitory concentration: 150 nM
Compound 4: middle estimate off by 2.5-fold (0.40 log units), on the low side; measured number inside the range.
By their numbers in this assay, from the lowest: compounds 1 and 3 (each within the scatter of the next); then compound 4. At a limit, above all of these: compound 2.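

A change on the sulfonyl sulfur is not neutral in this assay: 3-hydroxypiperidin-1-yl in place of oxan-4-yl gives a 4.3-fold higher number from compound 3 to compound 4 (0.63 log units; beyond the scatter) on an otherwise unchanged structure. The entering group brings a ring nitrogen, a hydrogen-bond donor and a defined stereocentre together, so this single pair cannot separate them. Nothing measured here accounts for the step.

Still open, going by these compounds, is how piperidin-1-yl without the hydroxyl group would read in this assay, and how the opposite stereoisomer of 3-hydroxypiperidin-1-yl would compare with compound 4.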